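Replacing pyridin-4-yl with phenyl in compound 2

The compounds below may be only part of what the source reports. "The series", "measured", "known", "first", "only" and "open" are said of these compounds alone.

Of the compounds shown here, two with a shared core have been measured in a functional assay on KB cells (Homo sapiens) for antiproliferative activity, read by sulforhodamine B assay, with a stated time of 3 days; a higher number here means a weaker inhibitor of growth, a lower number a stronger inhibitor of growth. Compound 1 `CN1CCC(C(=O)Nc2cccc(Nc3ncc(F)c(Nc4ccc(F)cc4)n3)c2)CC1` gives 1700 nM. Compound 2 `O=C(Nc1cccc(Nc2ncc(F)c(Nc3ccc(F)cc3)n2)c1)c1ccncc1` gives 5280 nM, the higher of the two numbers and so the weaker growth inhibitor. Compound 3 `O=C(Nc1cccc(Nc2ncc(F)c(Nc3ccc(F)cc3)n2)c1)c1ccccc1` differs from compound 2 in one group: phenyl in place of pyridin-4-yl on a carbonyl carbon. Both groups are six-membered aromatic rings. Within the data shown here, the only measured step touches this same place, a 3.1-fold higher number from compound 1 to compound 2 (0.49 log units; beyond the scatter), a modest change from a group that is not aromatic. Among the measured compounds shown here, no measured step exchanges one aromatic ring for another, so that step gives only a rough guide to size and none to direction. In this assay, a small change within the scatter is therefore expected, a 1.2-fold lower number from compound 2 to compound 3 (0.07 log units; within the scatter). For compound 3 the estimated value is 4500 nM, within an expected range of 1800 nM to 11000 nM.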

Compound 3, concentration for 50% growth inhibition: > 10000 nM
Compound 3: only a limit was reported (the forecaster's own chance of this, stated with the estimate: 8%); at least 2.2-fold (0.34 log units) between middle value and limit.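

In this assay compound 3 gives > 10000 nM, which is a limit and not a number. Putting phenyl in place of pyridin-4-yl gives an at least 1.8-fold higher number from compound 2 to compound 3 (0.27 log units; that floor lies within the scatter), so a real loss from this swap is possible but not shown. The firmer reading comes from the comparison with the group that is not aromatic, an at least 5.8-fold higher number from compound 1 to compound 3 (0.76 log units; beyond the scatter), which leaves compound 1, with its 1-methylpiperidin-4-yl on the carbonyl carbon, with the lowest number of the three.

Whether an open-chain amine or a carboxylic acid on this carbonyl carbon would match compound 1 stays open among the compounds shown. How far compound 3 lies past its reported limit also stays open, and the measurement stops at this point: the limit of > 10000 nM in this assay, at which 1 of the 3 values shown sits.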